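Aryl carbamate series: halogen to methoxy exchange

The source may hold more compounds than are shown below. What is called first, only, known or untested is meant among the compounds shown, and "the series" means these compounds.

compound 1 `C=C1C(=O)OC[C@H]1CCOC(=O)Nc1ccc(I)cc1`: 490 nM
compound 2 `C=C1C(=O)OC[C@H]1CCOC(=O)Nc1ccc(Br)cc1`: 350 nM

In a functional assay on RAW264.7 cells (Mus musculus) for inhibition, with a stated time of 30 min (on this read-out higher numbers stand for weaker inhibition and lower numbers for stronger inhibition), compound 2 and compound 1 lie within the scatter of each other; the step of a 1.4-fold lower number from compound 1 to compound 2 (0.15 log units; within the scatter) is the only measured one. Compound 3 `C=C1C(=O)OC[C@H]1CCOC(=O)Nc1ccc(OC)cc1` carries methoxy in place of bromo on an aromatic carbon. The halogen step bears on this only loosely, as an exchange of the group on the same aromatic carbon, and it was small. Among the compounds with values here, no step from a halogen to methoxy is on hand, so no shift beyond the scatter is expected in either direction. Compound 3 is expected at 500 nM, within 200 nM to 1500 nM. The expected step is a 1.4-fold higher number from compound 2 to compound 3 (0.15 log units; within the scatter).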

Compound 3, half-maximal inhibitory concentration: 710 nM
Compound 3: the middle estimate sits 1.4-fold (0.15 log units) below what was measured, and the stated range covers the measured number.
By their numbers in this assay, from the lowest: compounds 2, 1 and 3 (each within the scatter of the next, the first and the last beyond it).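

Methoxy on this aromatic carbon, para to a large group, gives the only step here that lies beyond the scatter in this assay: a 2.0-fold higher number from compound 2 to compound 3 (0.31 log units; beyond the scatter), a modest one. Against iodo, the same exchange stays within the scatter: a 1.4-fold higher number from compound 1 to compound 3 (0.16 log units; within the scatter). The size of the effect therefore depends on which halogen serves as the reference, and no measurement on hand accounts for the bromo to methoxy difference.

As far as these compounds go, whether an amine, a carboxylic acid or a longer alkoxy chain on this carbon would keep the number in this range remains open. So does the effect of fluoro or chloro here.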